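The source may hold more compounds than are shown below. What is called first, only, known or untested is meant among the compounds shown, and "the series" means these compounds.

Compound 1 `CCOC(=O)c1sc2cc(Oc3ccnc(C(=O)NC)c3)ccc2c1C` gives > 100000 nM in an ADME assay on HeLa cells (Homo sapiens) for cytotoxicity, read by MTT assay, with a stated time of 2 days (on this read-out higher numbers stand for lower toxicity in this test and lower numbers for higher toxicity in this test), a limit of the assay rather than a number.
Compound 2 `CNC(=O)c1cc(Oc2ccc3c(C)c(C(=O)OC)sc3c2)ccn1` gives 15700 nM in this assay.
Compound 3 `CNC(=O)c1cc(Oc2ccc3ccc(C(=O)OC(C)C)cc3c2)ccn1` gives 8700 nM in this assay.

Compound 4 `CCC(C)OC(=O)c1ccc2ccc(Oc3ccnc(C(=O)NC)c3)cc2c1` has not been measured. The difference between the cores of compound 2 and compound 3 is not broken down here. Between compound 2 and compound 1 the change is methyl in place of hydrogen on a saturated chain carbon bound to an oxygen next to a carbonyl group, and this gave an at least 6.3-fold higher number from compound 2 to compound 1 (0.80 log units; beyond the scatter), where compound 1 sits at the limit of > 100000 nM in this assay, at which 1 of the 3 values shown sits. From compound 3 to compound 4 the change is methyl in place of hydrogen on a saturated chain carbon, two bonds along the chain from an oxygen next to a carbonyl group; it is the same kind of change, but the place is not the same, as the methyl now enters two bonds along the chain from the oxygen rather than on the carbon bound to it. Resting on that earlier step, compound 4 is expected to show a 2.3-fold higher number from compound 3 to compound 4 (0.36 log units; beyond the scatter) in this assay, a smaller step than before. Compound 4 is estimated at 20000 nM, between 7000 nM and 60000 nM.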

Compound 4, half-maximal cytotoxic concentration: 9000 nM
For compound 4 the middle estimate is 2.2-fold (0.35 log units) above the measured one; low and high end bracket the measured number.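

In this assay the methyl in place of hydrogen gave a 1.0-fold higher number from compound 3 to compound 4 (0.01 log units; within the scatter), so the earlier step did not carry over in size to this core: the same change on two cores in this assay, an at least 6.3-fold higher number (0.80 log units; beyond the scatter) from compound 2 to compound 1 and a 1.0-fold higher number (0.01 log units; within the scatter) from compound 3 to compound 4, at least 6.1-fold (0.78 log units) apart, beyond the scatter of two such steps. The earlier step ends at compound 1, whose value is a limit of the assay: the limit of > 100000 nM in this assay, at which 1 of the 4 values shown sits. This does not show whether the core or the place of the methyl sets the two steps apart, since both differ: the methyl now stands two bonds along the chain from the oxygen, not on the carbon bound to it.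

The compounds shown leave open what a methyl two bonds along the chain would give on the core of compound 2. They also leave open how a longer chain or a carboxylic acid would read in this assay.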